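The source may hold more compounds than are shown below. What is called first, only, known or untested is meant among the compounds shown, and "the series" means these compounds.

Of the compounds shown here, three of one series have been tested in an ADME assay on Huh-7 cells (Homo sapiens) for cytotoxicity, read by XTT assay, with a stated time of 3 days, tested at 200 uM (on this read-out lower numbers stand for a stronger effect and higher numbers for a weaker effect at the one concentration tested), and a fourth awaits its number. Compound 1, `Fc1ccc(-c2cc(-c3ccc4cc(F)ccc4n3)nn2-c2ccccc2)cc1`, gives 89.7% in this assay. Compound 2, `COc1ccc(-c2cc(-c3ccc4cc(F)ccc4n3)nn2-c2ccccc2)cc1`, gives 93.7% in this assay and differs from compound 1 by one change:

methoxy in place of fluoro on an aromatic carbon

That change moves the read-out by a number 4 percentage points higher from compound 1 to compound 2 (within the scatter). Compound 3, `NS(=O)(=O)c1ccc(-n2nc(-c3ccc(F)cc3)cc2-c2ccc3cc(F)ccc3n2)cc1`, gives 43%, the lowest of the three numbers; the difference between its core and the core of compound 1 is not broken down here. Compound 4, `COc1ccc(-c2cc(-c3ccc4cc(F)ccc4n3)n(-c3ccc(S(N)(=O)=O)cc3)n2)cc1`, has not yet been measured. It differs from compound 3 by the same change seen between compound 1 and compound 2: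

methoxy in place of fluoro on an aromatic carbon

The surroundings of the change read the same in both pairs, so the change is taken as the same. Since compound 2 stayed within the scatter of compound 1 after this change, the step from compound 3 to compound 4 is expected to be small as well, about a number 4 percentage points higher from compound 3 to compound 4 (within the scatter). Compound 4 is therefore estimated at 47%, with a likely range from 30% to 65%, because compound 3 sits at 43% and the earlier step of a number 4 percentage points higher from compound 1 to compound 2 (within the scatter) was modest.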

Compound 4, a percentage reported as activity, at one concentration (the size of the read-out at that concentration, not a potency): 89.5%
Estimate against measurement, compound 4: 42.5 percentage points below; the whole stated range lies below it.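

In this assay, replacing fluoro with methoxy on the core of compound 3, the change from 4-fluorophenyl to 4-methoxyphenyl, gives a number 46.5 percentage points higher from compound 3 to compound 4 (beyond the scatter). The same change therefore did not carry over with the same size from one core to the other: the same change on two cores in this assay, a number 4 percentage points higher (within the scatter) from compound 1 to compound 2 and a number 46.5 percentage points higher (beyond the scatter) from compound 3 to compound 4, 42.5 percentage points apart, beyond the scatter of two such steps. This shows that, in these two pairs, the size of the step depends on the core it is made on, but it does not show which difference between the two cores matters, and two pairs give no rule for any further core in the series.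

The compounds shown leave open how other groups in the same place would read on either core, such as an amine, a chloro group or a longer ether like ethoxy. They also leave open whether a third core would follow the small step, the large step or neither.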